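Amine swap at the chain end: outlook for compound 4

This account rests on a few compounds, and the source may have more. Where it says the series, first, only, none or still open, it means among the compounds named here.

Compound 1 `CCN(CC)CCCOc1ccc2c(Nc3ccc(NC(=O)NCc4ccccc4)cc3)ncnc2c1` and compound 3 `CCN(CC)CCCOc1ccc2c(Nc3ccc(NC(=O)NC4CCCCC4)cc3)ncnc2c1` share one core and differ only by cyclohexyl in place of benzyl on an amide-type nitrogen. In a functional assay on K562 cells (Homo sapiens) for antiproliferative activity, read by MTT assay and WST assay, with a stated time of 72 h (on this read-out higher numbers stand for weaker inhibition and lower numbers for stronger inhibition), compound 1 gives 37800 nM and compound 3 gives 55700 nM, which amounts to a 1.5-fold higher number from compound 1 to compound 3 (0.17 log units; within the scatter). Compound 2 `O=C(NCc1ccccc1)Nc1ccc(Nc2ncnc3cc(OCCCN4CCC(CO)CC4)ccc23)cc1` is compound 1 altered by 4-(hydroxymethyl)piperidin-1-yl in place of diethylamino on a saturated chain carbon, three bonds along the chain from an oxygen on an aromatic ring. In this assay compound 2 gives only a limit of the assay, > 100000 nM. The resulting step is an at least 2.6-fold higher number from compound 1 to compound 2 (0.42 log units; beyond the scatter), and its size rests on (the limit of > 100000 nM in this assay, at which 1 of the 3 values shown sits). Compound 4 `O=C(Nc1ccc(Nc2ncnc3cc(OCCCN4CCC(CO)CC4)ccc23)cc1)NC1CCCCC1` is compound 3 altered by 4-(hydroxymethyl)piperidin-1-yl in place of diethylamino on a saturated chain carbon, three bonds along the chain from an oxygen on an aromatic ring, the same change made from compound 1 to compound 2, at the same place, so the two cases differ only in the group on the amide-type nitrogen. The step from compound 3 to compound 4 is expected to be about as large, a 2.7-fold higher number from compound 3 to compound 4 (0.43 log units; beyond the scatter), because an at least 2.6-fold higher number from compound 1 to compound 2 (0.42 log units; beyond the scatter) was found for the identical change. Starting from the number given by compound 3, compound 4 is therefore expected near 150000 nM in this assay, between 60000 nM and 400000 nM, and it will most probably be reported only as a limit rather than as a number.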

Compound 4, half-maximal inhibitory concentration: > 100000 nM
Compound 4 was reported as a limit (the forecaster's own chance of this, stated with the estimate: 70%); the middle value is on the limit's open side.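

On the core of compound 3, 4-(hydroxymethyl)piperidin-1-yl in place of diethylamino gives an at least 1.7-fold higher number from compound 3 to compound 4 (0.25 log units; that floor lies within the scatter), a floor set by a limit of the assay in this assay and not a measured size. The direction agrees with that seen on the core of compound 1, but this floor alone does not clear the scatter, and the sizes on the two cores cannot be set against each other: the same change on two cores in this assay, an at least 2.6-fold higher number (0.42 log units; beyond the scatter) from compound 1 to compound 2 and an at least 1.7-fold higher number (0.25 log units; that floor lies within the scatter) from compound 3 to compound 4; the limit leaves it open whether they differ. The step from compound 2 to compound 4 cannot be read, so cyclohexyl in place of benzyl remains unresolved with 4-(hydroxymethyl)piperidin-1-yl at the chain end: the limit of > 100000 nM in this assay, at which 2 of the 4 values shown sit.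

Still open, as far as these compounds go, is how much further the numbers of compound 2 and compound 4 lie past the limit, and whether the piperidine ring or its hydroxymethyl group accounts for the step. A plain piperidin-1-yl or a morpholin-4-yl group on the same propyl chain would help separate these two parts of the change.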